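The compounds below may be only part of what the source reports. "The series", "measured", "known", "first", "only" and "open" are said of these compounds alone.

Measured compounds in an assay on isolated protein for inhibition of complement C1r subcomponent (Homo sapiens); a lower number here means a stronger inhibitor, a higher number a weaker inhibitor:
compound 1, `O=c1oc(Nc2ccccc2Br)nc2ccccc12`, 5100 nM
compound 2, `O=c1oc(Nc2ccccc2I)nc2cc(Cl)cc(Cl)c12`, > 62500 nM
compound 3, `Cc1ccc2c(=O)oc(Nc3ccccc3I)nc2c1`, 800 nM

Within the data shown here, of these, compound 2 stands apart: its entry is a limit of the assay, not a number, and it is the one value that sits at the limit of > 62500 nM in this assay, at which 1 of the 3 values shown sits. Two numbers remain. Compound 3 holds the lower of them, and compound 1, which carries no substituent on the fused ring and bears bromine rather than iodine on the aniline, sits higher by a margin that lies beyond the scatter. Compound 3 is therefore the starting point, and what follows is the step from compound 3 to the unmeasured compound 4, `O=c1oc(Nc2ccccc2I)nc2cc(C3CCCCC3)ccc12`. The change is cyclohexyl in place of methyl on an aromatic carbon. Among the measured compounds shown here, the methyl that marked compound 3 out from compound 1 is replaced by a far larger saturated ring at the same place, and no measured pair shows a change of this kind, so the direction is open. The expected step from compound 3 to compound 4 in this assay is a 1.9-fold higher number from compound 3 to compound 4 (0.27 log units; within the scatter), a modest loss that stays close to the scatter. Compound 4 is estimated at 1500 nM, with a range from 300 nM to 10000 nM.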

Compound 4, half-maximal inhibitory concentration: > 62500 nM
Compound 4 ended at the assay's limit; the forecaster's own chance of this, stated with the estimate: 10%; at least 41-fold (1.61 log units) between middle value and limit.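

In this assay, among these compounds, cyclohexyl in place of methyl on this aromatic carbon gives an at least 78-fold higher number from compound 3 to compound 4 (1.89 log units; beyond the scatter), and this is the first pair in the set that differs in one place, so it is the first direct reading of this position. From the compounds shown here alone, the entry of compound 4, > 62500 nM, is a limit of the assay and not a number, and the full size of the step stays unknown. On this carbon the shared core thus keeps a measurable value with methyl but not with cyclohexyl, and compound 4 now stands at the same limit as compound 2: the limit of > 62500 nM in this assay, at which 2 of the 4 values shown sit.

Going by these compounds, what remains open is where between methyl and cyclohexyl the loss sets in, which an ethyl, an isopropyl or a cyclopropyl on this carbon would help to place. Also open, on these data alone, is how a morpholine or a carboxylic acid would behave here, and how much of the gap between compound 1 and compound 3 belongs to the methyl and how much to the iodine, as those two compounds differ in more than one place.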